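Two triazole amides and an untested phenoxyethyl analogue

The source may hold more compounds than are shown below. What is called first, only, known or untested is meant among the compounds shown, and "the series" means these compounds.

Among the compounds with values here, compound 2, `C[C@H](NC(=O)c1c(-c2ccccc2)nnn1Cc1ccc(F)c(F)c1)c1ccc(C(=O)O)cc1`, is the only compound of the pair to give a number in a functional assay on CHO cells for antagonist activity at prostaglandin E2 receptor EP4 subtype (Homo sapiens), read by calcium flux, with a stated time of 15 min (on this read-out higher numbers stand for weaker inhibition and lower numbers for stronger inhibition), where compound 2 shows 148 nM. Compound 1, `CCc1nnn(Cc2ccc(C(F)(F)F)cc2)c1C(=O)N[C@@H](C)c1ccc(C(=O)O)cc1`, returns only a limit in this assay, > 10000 nM, which sits at the limit of > 10000 nM in this assay, at which 1 of the 2 values shown sits. Compound 3, `C[C@H](NC(=O)c1c(-c2ccccc2)nnn1CCOc1ccc(F)cc1)c1ccc(C(=O)O)cc1`, has not been measured in this assay. It differs from compound 2 by (4-fluorophenoxy)methyl in place of 3,4-difluorophenyl on a saturated chain carbon bound to an aromatic nitrogen. Within the data shown here, no measured pair differs in just one place, so there is no directly comparable step to draw on. The change keeps the same acid and amide portion and the same phenyl group on the shared core, altering only the group on the saturated chain carbon bound to an aromatic nitrogen. The estimate for compound 3 in this assay is therefore anchored on compound 2, with a step from compound 2 to compound 3 expected to be a 2.4-fold higher number from compound 2 to compound 3 (0.37 log units; beyond the scatter), toward weaker inhibition but not beyond a moderate loss. Compound 3 is expected to give 350 nM, within the range from 90 nM to 1500 nM.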

Compound 3, half-maximal inhibitory concentration: 3.1 nM
Beside the measured number, compound 3's estimate is 110-fold (2.05 log units) above it; measured number below the stated range.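

In this assay, (4-fluorophenoxy)methyl in place of 3,4-difluorophenyl on a saturated chain carbon bound to an aromatic nitrogen brings a 48-fold lower number from compound 2 to compound 3 (1.68 log units; beyond the scatter). This is the first single-place step shown, and it establishes that this position can strongly change inhibition while the acid and amide portion and the phenyl group on the shared core stay the same. Nothing measured here accounts for the size of this step.

The entering group differs from the leaving group in its oxygen, its fluorine count and its ring substitution all at once, so the compounds shown do not separate these differences. Going by these compounds, it remains open how inhibition would respond to an unsubstituted 2-phenoxyethyl group, or to a 3-(4-fluorophenyl)propyl group with a carbon in place of the oxygen, at this position.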